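Replacing methyl(pentyl)amino with 4-methylpiperazin-1-yl on a carbonyl carbon

The source may hold more compounds than are shown below. What is called first, only, known or untested is meant among the compounds shown, and "the series" means these compounds.

Measured in a functional assay on DU-145 cells (Homo sapiens) for antiproliferative activity, read by sulforhodamine B assay, with a stated time of 48 h; a higher number here means a weaker inhibitor, a lower number a stronger inhibitor:
- Compound 1 `COc1ccc(-c2oc3c(OC)c(OC)cc(OCCCC(=O)NCc4ccccn4)c3c(=O)c2O)cc1`: > 40000 nM (a limit)
- Compound 2 `COc1ccc(-c2oc3c(OC)c(OC)cc(OCCCC(=O)N4CCN(C)CC4)c3c(=O)c2O)cc1`: > 40000 nM (a limit)
- Compound 3 `CCCCCN(C)C(=O)CCCCCOc1cc(OC)c(OC)c2oc(-c3ccc(OC)cc3)c(O)c(=O)c12`: 22500 nM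

Only compound 3 has an actual number, 22500 nM, in this assay. Compound 1 reads > 40000 nM, which is a limit. Compound 2 reads > 40000 nM, which is also a limit. The series is therefore framed by the limit of > 40000 nM in this assay, at which 2 of the 3 values shown sit.

Compound 4 `COc1ccc(-c2oc3c(OC)c(OC)cc(OCCCCCC(=O)N4CCN(C)CC4)c3c(=O)c2O)cc1` differs from compound 3 in one place: 4-methylpiperazin-1-yl in place of methyl(pentyl)amino on a carbonyl carbon. In words, 4-methylpiperazin-1-yl stands in place of methyl(pentyl)amino on a carbonyl carbon.

Among the measured compounds shown here, no measured step isolates this change. Compound 2 carries the same 4-methylpiperazin-1-yl, but an at least 1.7-fold lower number from compound 2 to compound 3 (0.24 log units; that floor lies within the scatter) also involves the chain. The step of an at least 1.7-fold lower number from compound 1 to compound 3 (0.24 log units; that floor lies within the scatter) is of the same limited kind, and a step that the two limits leave unreadable from compound 1 to compound 2 gives no size at all. Nothing beyond the scatter is therefore expected, with a slight lean towards a higher number, given compound 2 at > 40000 nM. The expected step is a 1.4-fold higher number from compound 3 to compound 4 (0.15 log units; within the scatter). For compound 4 the estimated value is 32000 nM, with an expected range from 15000 nM to 55000 nM.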

Compound 4, half-maximal inhibitory concentration: 13200 nM
Estimate against measurement, compound 4: 2.4-fold (0.38 log units) above; measured number outside the range, below it.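

In this assay, the exchange of methyl(pentyl)amino for 4-methylpiperazin-1-yl on a carbonyl carbon, now seen on its own, gives a 1.7-fold lower number from compound 3 to compound 4 (0.23 log units; within the scatter), so the two groups are not told apart at this position. Chain length matters more: with 4-methylpiperazin-1-yl kept, the change from (4-methylpiperazin-1-yl)carbonyl to 2-((4-methylpiperazin-1-yl)carbonyl)ethyl gives an at least 3.0-fold lower number from compound 2 to compound 4 (0.48 log units; beyond the scatter), and the step that changes chain and amide group together gives an at least 3.0-fold lower number from compound 1 to compound 4 (0.48 log units; beyond the scatter). Both of these steps are floors and not full sizes because compound 1 and compound 2 each stand at a limit: the limit of > 40000 nM in this assay, at which 2 of the 4 values shown sit.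

The compounds shown leave open whether ((pyridin-2-yl)methyl)amino would behave like 4-methylpiperazin-1-yl on the longer chain. They also leave open how a carboxylic acid, a morpholin-4-yl amide or a still longer chain would read here.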